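Naphthalenesulfonamide series: ring-substituent changes on the amine nitrogen

A few compounds are considered here, and "the series" means these few. Any claim that something is new, unique, unknown or untested is made for them only; others in the source may bear on it.

Measured in an assay on VSM-A10 cells for antagonist activity at Endothelin-1 receptor (Rattus norvegicus); on this read-out lower numbers stand for stronger inhibition and higher numbers for weaker inhibition:
- compound 1 `Cc1noc(NS(=O)(=O)c2cccc3c(NCCCCCc4ccccc4)cccc23)c1C` gives 3050 nM
- compound 2 `Cc1noc(NS(=O)(=O)c2cccc3c(N4CCCCC4=O)cccc23)c1C` gives 270 nM
- compound 3 `Cc1noc(NS(=O)(=O)c2cccc3c(N/C(S)=N/c4ccccc4)cccc23)c1C` gives 150 nM

Compound 3 has the lowest number of the three; the gap to compound 2 is within the scatter, the gap to compound 1 is beyond it. Compound 4 `CCOC(=O)C(C)Nc1cccc2c(S(=O)(=O)Nc3onc(C)c3C)cccc12` differs from compound 3 in one place: a group of 7 heavy atoms (5 carbon, 2 oxygen; no ring) in place of a group of 9 heavy atoms (7 carbon, 1 nitrogen, 1 sulfur; one six-membered aromatic ring of carbon only), on a nitrogen on an aromatic ring. Of the measured steps, the one on the same nitrogen is a 20-fold lower number from compound 1 to compound 3 (1.31 log units; beyond the scatter), where a ring-bearing hydrocarbon chain was replaced by the thiourea group; the step of a 1.8-fold lower number from compound 2 to compound 3 (0.26 log units; within the scatter) sits on an aromatic carbon and is only indirectly relevant, showing the site tolerates varied groups without large change. Compound 4 carries a short ring-free chain on that nitrogen, closer in kind to compound 1 than to compound 3, so in this assay a higher number than for compound 3 is expected, though likely less extreme than for compound 1. The estimated step is a 5.3-fold higher number from compound 3 to compound 4 (0.73 log units; beyond the scatter). Compound 4 is expected to give 800 nM, within the range 250 nM to 2500 nM.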

Compound 4, half-maximal inhibitory concentration: 400 nM
Compound 4: the middle estimate sits 2.0-fold (0.30 log units) above what was measured; the range from low to high includes it.
By their numbers in this assay, from the lowest: compounds 3, 2 and 4 (each within the scatter of the next, the first and the last beyond it); then compound 1.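

In this assay, the ring-free 1-(ethoxycarbonyl)ethyl on the nitrogen gives a 7.6-fold lower number from compound 1 to compound 4 (0.88 log units; beyond the scatter) when it replaces 5-phenylpentyl, yet a 2.7-fold higher number from compound 3 to compound 4 (0.43 log units; beyond the scatter) when it replaces the group of compound 3, so among these compounds a ring on this nitrogen is neither needed for a number well under that of compound 1 nor enough to secure one. Compared with 2-oxopiperidin-1-yl on the aromatic carbon, (1-(ethoxycarbonyl)ethyl)amino gives a 1.5-fold higher number from compound 2 to compound 4 (0.17 log units; within the scatter) and the two cannot be told apart on this read-out. No supporting measurement is available to explain these differences.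

As far as these compounds go, it remains open how a carboxylic acid in place of the ethoxycarbonyl would compare. The same holds for a longer chain carrying the ethoxycarbonyl, or a chain ending in an amine, on this nitrogen.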